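From Heptyl to 1-Cyclohexylethyl on the Shared Core

This account rests on a few compounds, and the source may have more. Where it says the series, first, only, none or still open, it means among the compounds named here.

In a functional assay for inhibition, with Rattus norvegicus as the target (a higher number here means a weaker inhibitor, a lower number a stronger inhibitor), compound 3 (`CCCCCCC/N=c1\c(O)c(O)\c1=N/c1ccc(C#N)cc1`) gives > 30000 nM, which is a limit of the assay and not a number. Compound 1 (`CCC(CC)/N=c1\c(O)c(O)\c1=N/c1ccc(C#N)cc1`) gives 3340 nM and compound 2 (`CCC(C)/N=c1\c(O)c(O)\c1=N/c1ccc(C#N)cc1`) gives 2100 nM, the step between them being a 1.6-fold lower number from compound 1 to compound 2 (0.20 log units; within the scatter). Compound 4 (`C[C@@H](/N=c1\c(O)c(O)\c1=N/c1ccc(C#N)cc1)C1CCCCC1`) carries 1-cyclohexylethyl in place of heptyl on a double-bonded nitrogen. Among the measured compounds shown here, two measured steps bear on this change, an at least 8.9-fold higher number from compound 1 to compound 3 (0.95 log units; beyond the scatter) and an at least 14-fold higher number from compound 2 to compound 3 (1.15 log units; beyond the scatter). For the measured compounds named here, each puts heptyl where a branched group stood, and compound 4 reverses that kind of change, though its ring has no measured precedent. A step of similar size in the opposite direction is therefore expected, an at least 15-fold lower number from compound 3 to compound 4 (1.17 log units; beyond the scatter). For compound 4 the estimated value is 2000 nM, with an expected range of 500 nM to 10000 nM.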

Compound 4, half-maximal inhibitory concentration: 2600 nM
Compound 4: the middle estimate sits 1.3-fold (0.11 log units) below what was measured; low and high end bracket the measured number.
By their numbers in this assay, from the lowest: compounds 2, 4 and 1 (each within the scatter of the next). At a limit, above all of these: compound 3.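

In this assay, a ring-bearing branched group on the double-bonded nitrogen is tolerated, and the loss seen with heptyl does not return: an at least 11-fold lower number from compound 3 to compound 4 (1.06 log units; beyond the scatter). Set against the sec-butyl and pentan-3-yl groups, 1-cyclohexylethyl shows no difference beyond the scatter: a 1.2-fold higher number from compound 2 to compound 4 (0.09 log units; within the scatter) and a 1.3-fold lower number from compound 1 to compound 4 (0.11 log units; within the scatter). Among the four compounds, the three branched groups therefore stand together, and only straight heptyl stands apart.

From the compounds shown here alone, how large the step from heptyl really is stays open, as compound 3 is held at a limit: the limit of > 30000 nM in this assay, at which 1 of the 4 values shown sits. Also open is whether a shorter straight chain such as butyl, a phenyl ring in place of cyclohexyl, or the opposite configuration at the stereocentre would hold this level.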